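The compounds below may be only part of what the source reports. "The series", "measured", "known", "first", "only" and "open" are said of these compounds alone.

Measured compounds:

Compound 1, `Brc1ccc(OCCOc2nc3ccccc3s2)cc1`, gives 94.6%.
Compound 2, `Brc1cccc(COc2nc3ccccc3s2)c1`, gives 77.6%.
Compound 3, `Clc1ccc(OCCOc2nc3ccccc3s2)cc1`, gives 66.3%.

All three values were obtained in a functional assay on the whole organism with Mus musculus as the target, with a stated time of 1 h, at a dose of 100 mg/kg by the intraperitoneal route; on this read-out higher numbers stand for more inhibition at the one dose given (going by the name of the read-out) and lower numbers for less inhibition. Compound 1 and compound 3 share a core and differ in one place: chloro in place of bromo on an aromatic carbon. That one change gave a number 28.3 percentage points lower from compound 1 to compound 3 (beyond the scatter). Within the data shown here, the difference between the core of compound 1 and the core of compound 2 is not broken down here; what can be said of the pair is only that compound 1 shows 94.6% and compound 2 shows 77.6%.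

Compound 4, `Clc1cccc(COc2nc3ccccc3s2)c1`, has not yet been measured in this assay . It relates to compound 2 the way compound 3 relates to compound 1: chloro in place of bromo on an aromatic carbon. The two changes are the same kind of change but not the same, since in compound 1 the halogen sits para to a large group, whereas in compound 2 it sits meta to a large group.

Because the measured pair gave a number 28.3 percentage points lower from compound 1 to compound 3 (beyond the scatter), a step of similar direction is expected from compound 2 to compound 4, namely a number 25.6 percentage points lower from compound 2 to compound 4 (beyond the scatter). The spread of this expectation is wide, since it rests on a single measured step made on a different core. Compound 4 is therefore expected to show about 52%, with a likely range from 30% to 72%.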

Compound 4, a percentage reported as inhibition, in the whole organism at one dose (the size of the read-out at that dose, not a potency): 80%
Compound 4: the middle estimate sits 28 percentage points below what was measured; the whole stated range lies below it.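

In this assay, putting chloro in place of bromo on the core of compound 2 gave a number 2.4 percentage points higher from compound 2 to compound 4 (within the scatter), so on this core the swap left the read-out essentially unchanged. This change therefore cannot be carried from one core to the other in this series as a fixed step, since the same swap behaved differently on the two cores: the same change on two cores in this assay, a number 28.3 percentage points lower (beyond the scatter) from compound 1 to compound 3 and a number 2.4 percentage points higher (within the scatter) from compound 2 to compound 4, 30.7 percentage points apart, beyond the scatter of two such steps. This does not show which feature of the two cores accounts for the gap, since they are not broken down into single changes here, and two steps cannot predict what the swap would do on a third core.

The compounds shown carry only bromo or chloro on that aromatic ring, which leaves open how fluoro, methoxy, an amine or a carboxylic acid would read at the same place, and what a longer chain between the ring and the shared end of the molecule would do. Each compound also appears at a single dose and a single time, so the figures give the size of the effect under those conditions and leave open how the compounds would compare in potency.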